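This account rests on a few compounds, and the source may have more. Where it says the series, first, only, none or still open, it means among the compounds named here.

Compound 1 `CC(=O)c1nn(-c2ccc(C)cc2)/c(=N/c2nc(-c3c(C)n(C)n(-c4ccccc4)c3=O)cs2)s1` gives 31700 nM in a functional assay on HepG2 cells (Homo sapiens) for cytotoxicity, read by sulforhodamine B assay, with a stated time of 72 h; on this read-out lower numbers stand for stronger inhibition and higher numbers for weaker inhibition.
Compound 2 `COc1ccc(-n2nc(C(C)=O)s/c2=N\c2nc(-c3c(C)n(C)n(-c4ccccc4)c3=O)cs2)cc1` gives 41300 nM in this assay.
Compound 3 `CC(=O)c1nn(-c2ccc([N+](=O)[O-])cc2)/c(=N/c2nc(-c3c(C)n(C)n(-c4ccccc4)c3=O)cs2)s1` gives > 100000 nM in this assay, which is a limit of the assay and not a number.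

In this assay compound 2 holds the higher of the two numbers, though compound 1 sits within the scatter of it: a 1.3-fold higher number from compound 1 to compound 2 (0.11 log units; within the scatter). The other two steps are larger: an at least 2.4-fold higher number from compound 2 to compound 3 (0.38 log units; beyond the scatter) and an at least 3.1-fold higher number from compound 1 to compound 3 (0.49 log units; beyond the scatter), with compound 3 resting at a limit (the limit of > 100000 nM in this assay, at which 1 of the 3 values shown sits). Compound 4 `CCOC(=O)c1nn(-c2ccc(OC)cc2)/c(=N/c2nc(-c3c(C)n(C)n(-c4ccccc4)c3=O)cs2)s1` differs from compound 2 in a single place: ethoxy in place of methyl on a carbonyl carbon. Every measured step, by contrast, swaps the group on an aromatic carbon and leaves the acetyl untouched, so none of them bears on this change. The expectation therefore rests on compound 2 alone, with a wide margin, and no step beyond the scatter is expected from compound 2 to compound 4 in this assay: a 1.1-fold higher number from compound 2 to compound 4 (0.04 log units; within the scatter). Compound 4 is thus estimated at 45000 nM, within a range from 15000 nM to 130000 nM.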

Compound 4, half-maximal inhibitory concentration: 12900 nM
Beside the measured number, compound 4's estimate is 3.5-fold (0.54 log units) above it, and the stated range ends above it.
By their numbers in this assay, from the lowest: compound 4; then compounds 1 and 2 (each within the scatter of the next). At a limit, above all of these: compound 3.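

Ethoxy in place of methyl on a carbonyl carbon, which turns acetyl into ethoxycarbonyl, gives a step beyond the scatter in this assay: a 3.2-fold lower number from compound 2 to compound 4 (0.51 log units; beyond the scatter). Among the compounds shown here, the earlier steps all swapped the group on an aromatic carbon and left the acetyl untouched, so this is the first sign that the group on the carbonyl carbon also moves the number on this read-out, here towards stronger inhibition. Nothing measured among these compounds speaks to why this change has this effect.

Among the compounds shown, the change appears only with methoxy on the aromatic carbon, so whether it has a similar effect with methyl or nitro there stays open. Also open, on these data alone, is how an amine, a carboxylic acid or a longer chain would stand on the same carbonyl carbon.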